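A few compounds are considered here, and "the series" means these few. Any claim that something is new, unique, unknown or untested is made for them only; others in the source may bear on it.

Of the compounds shown here, three sharing one core have been measured in a functional assay on A549 cells (Homo sapiens) for cytotoxicity, read by MTT assay, with a stated time of 24 h, tested at 20 uM; on this read-out higher numbers stand for a weaker effect at the one concentration tested and lower numbers for a stronger effect. Compound 1 `CCCOC(=O)CCC(=O)N1CCN(CCCOc2cc3c(Nc4ccc(F)c(Cl)c4)ncnc3cc2OC)CC1` gives 87%. Compound 2 `CCCCCOC(=O)CCC(=O)N1CCN(CCCOc2cc3c(Nc4ccc(F)c(Cl)c4)ncnc3cc2OC)CC1` gives 81.2%. Compound 3 `CCCCCCCCCCCOC(=O)CCC(=O)N1CCN(CCCOc2cc3c(Nc4ccc(F)c(Cl)c4)ncnc3cc2OC)CC1` gives 85.2%. On these numbers compound 3 stands second highest of the three, nearest to compound 1 and furthest from compound 2, and both of those gaps lie within the scatter. Compound 4 `CCCCCCCCCCCCCCCCCCOC(=O)CCC(=O)N1CCN(CCCOc2cc3c(Nc4ccc(F)c(Cl)c4)ncnc3cc2OC)CC1` has not yet been measured. It differs from compound 3 in one place: heptyl in place of hydrogen on a saturated chain carbon, ten or more bonds along the chain from an oxygen next to a carbonyl group. The measured steps that altered the same part of the molecule all stayed within the scatter: a number 5.8 percentage points lower from compound 1 to compound 2 (within the scatter), a number 1.8 percentage points lower from compound 1 to compound 3 (within the scatter) and a number 4 percentage points higher from compound 2 to compound 3 (within the scatter). With three such steps showing no movement beyond the scatter, no step beyond the scatter is expected here either. The step this estimate means is expected to be a number 0.2 percentage points lower from compound 3 to compound 4 (within the scatter). For compound 4 the expected value in this assay is 85%, with a range from 75% to 95%.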

Compound 4, a percentage reported as activity, at one concentration (the size of the read-out at that concentration, not a potency): 90.5%
Compound 4: the middle estimate sits 5.5 percentage points below what was measured; the measured number falls inside the stated range.
By their numbers in this assay, from the lowest: compounds 2, 3, 1 and 4 (each within the scatter of the next).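

In this assay, heptyl in place of hydrogen on a saturated chain carbon, ten or more bonds along the chain from an oxygen next to a carbonyl group, gives a number 5.3 percentage points higher from compound 3 to compound 4 (within the scatter). The earlier compounds shown here tested this chain only as far as compound 3; compound 4 carries the test further out along the chain, and all four compounds still read alike at this position at the one concentration tested. No evidence at hand bears on this result.

From the compounds shown here alone, a reading at one concentration gives no potency, so whether these compounds would separate at other concentrations stays open. How an amine or a carboxylic acid in place of the alkyl chain would read also stays open, since the compounds shown speak only for plain alkyl chains.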